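The source may report more compounds than this note shows. Statements on the series, on what has been measured and on what is new or still open speak of the compounds shown alone.

Compound 1 `COc1ccc(OC)c(/C=C/C(=O)Nc2cc3c(Nc4ccc(F)c(Cl)c4)ncnc3cc2OC)c1`: 28600 nM
Compound 2 `COc1cc(/C=C/C(=O)Nc2cc3c(Nc4ccc(F)c(Cl)c4)ncnc3cc2O[C@H]2CCOC2)cc(OC)c1OC`: 20500 nM
Compound 3 `COc1ccc(OC)c(/C=C/C(=O)Nc2cc3c(Nc4ccc(F)c(Cl)c4)ncnc3cc2O[C@H]2CCOC2)c1`: 8730 nM
Compound 4 `COc1cc2ncnc(Nc3ccc(F)c(Cl)c3)c2cc1NC(=O)/C=C/c1ccc(C#N)cc1`: not yet measured

In a functional assay on PC-3 cells (Homo sapiens) for cytotoxicity, read by MTT assay, with a stated time of 72 h (a lower number here means a stronger inhibitor, a higher number a weaker inhibitor), compound 1 and compound 2 sit together at the weak end of this small set, within the usual scatter of each other. Compound 3 stands clear of compound 1, with a 3.3-fold lower number from compound 1 to compound 3 (0.52 log units; beyond the scatter).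

The next comparison moves from compound 1 to compound 4. The change is 4-cyanophenyl in place of 2,5-dimethoxyphenyl on a double-bonded chain carbon bound to a double-bonded chain carbon. The methyl on an oxygen stays, so a 3.3-fold lower number from compound 1 to compound 3 (0.52 log units; beyond the scatter) concerns a different place and gives only a sense of scale.

The closer guide is a 2.3-fold lower number from compound 2 to compound 3 (0.37 log units; beyond the scatter), a modest step that also changes the group at this place. Among the compounds with values here, it is a single example, however, and no measured compound carries a nitrile. The direction therefore stays uncertain, and a large change in this assay has no support in these data. The expected result, an estimate only, is a 1.4-fold lower number from compound 1 to compound 4 (0.16 log units; within the scatter). The estimated value for compound 4 is 20000 nM, with an expected range from 6000 nM to 60000 nM.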

Compound 4, half-maximal inhibitory concentration: "not active" (no number reported)
The entry for compound 4 holds no number; there is nothing to compare the estimate with.
By their numbers in this assay, from the lowest: compound 3; then compounds 2 and 1 (each within the scatter of the next).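

In this assay, within the data shown here, compound 4 is entered as "not active" without a number, so no step from compound 1 to compound 4 can be read. The compounds shown leave open how 4-cyanophenyl compares with 2,5-dimethoxyphenyl at this place in numbers. Nothing shown here offers an explanation for this entry.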